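Swapping a trifluoromethyl for chloro on a shared core

The compounds below may be only part of what the source reports. "The series", "measured", "known", "first", "only" and "open" are said of these compounds alone.

Of the compounds shown here, three built on one core have been tested in an ADME assay on BHK-21 cells (Mesocricetus auratus) for cytotoxicity, read by MTT assay, with a stated time of 72 h; on this read-out lower numbers stand for higher toxicity in this test and higher numbers for lower toxicity in this test. Compound 1, `FC(F)(F)c1ccc(NCc2cn(-c3ccccc3)nc2-c2ccc(C(F)(F)F)cc2)cc1`, gives 27000 nM in this assay. Compound 2, `FC(F)(F)c1ccc(NCc2cn(-c3ccccc3)nc2-c2ccc(Cl)cc2)cc1`, gives 17000 nM. Compound 3, `Cc1ccc(-c2nn(-c3ccccc3)cc2CNc2ccc(C(F)(F)F)cc2)cc1`, gives 88000 nM, the highest of the three numbers.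

Compound 2 differs from compound 1 only by chloro in place of trifluoromethyl on an aromatic carbon. That change gave a 1.6-fold lower number from compound 1 to compound 2 (0.20 log units; within the scatter). Compound 3 differs from compound 1 by methyl in place of trifluoromethyl on an aromatic carbon, a change that gave a 3.3-fold higher number from compound 1 to compound 3 (0.51 log units; beyond the scatter), while from compound 2 to compound 3 the step was a 5.2-fold higher number from compound 2 to compound 3 (0.71 log units; beyond the scatter).

Compound 4, `Cc1ccc(-c2nn(-c3ccccc3)cc2CNc2ccc(Cl)cc2)cc1`, is not yet measured. It differs from compound 3 by chloro in place of trifluoromethyl on an aromatic carbon. This is the same change that led from compound 1 to compound 2, made on the core of compound 3 rather than on that of compound 1, and the surroundings of the changed position are described in the same words for both pairs.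

The step expected from compound 3 to compound 4 in this assay is a 1.5-fold lower number from compound 3 to compound 4 (0.17 log units; within the scatter), set beside the earlier one. That expectation rests on compound 1 and compound 2, whose step a 1.6-fold lower number from compound 1 to compound 2 (0.20 log units; within the scatter) lay within the scatter, so little movement is foreseen. Compound 4 is therefore estimated to give 60000 nM, with a likely range from 25000 nM to 150000 nM.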

Compound 4, half-maximal cytotoxic concentration: > 100000 nM
Compound 4 ended at the assay's limit (the forecaster's own chance of this, stated with the estimate: 20%); at least 1.6-fold (0.22 log units) between middle value and limit.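

In this assay compound 4 gives > 100000 nM, which is a limit of the assay and not a number. On the core of compound 3, chloro in place of trifluoromethyl therefore gives only a floor, an at least 1.1-fold higher number from compound 3 to compound 4 (0.05 log units; that floor lies within the scatter), so the true size of the step stays unknown and the comparison with the same change on the core of compound 1 remains unsettled: the same change on two cores in this assay, a 1.6-fold lower number (0.20 log units; within the scatter) from compound 1 to compound 2 and an at least 1.1-fold higher number (0.05 log units; that floor lies within the scatter) from compound 3 to compound 4; the limit leaves it open whether they differ The result does not show that the change carries over unaltered from one core to the other, nor that it behaves differently on the two, and the single capped value is what stands in the way of either conclusion: the limit of > 100000 nM in this assay, at which 1 of the 4 values shown sits.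

The compounds shown leave open how the same swap of trifluoromethyl for chloro would read on a third core, for example one carrying a methoxy group or an amine where compound 1 has trifluoromethyl and compound 3 has methyl. They also leave open how a nitrile or a carboxylic acid would compare in this assay if placed where compound 3 carries trifluoromethyl and compound 4 carries chloro.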